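The source may hold more compounds than are shown below. What is called first, only, known or untested is meant among the compounds shown, and "the series" means these compounds.

For the measured compounds named here, compound 2 `COc1ccc(C(c2ccccc2)c2nc(-c3ccc(Cl)cc3)c(CC(=O)O)s2)cc1` is one of three compounds measured in an in vitro functional assay on HEK285-7 cells for antagonist activity at prostaglandin D2 receptor 2 (Homo sapiens), read by BRET and beta-arrestin recruitment (a higher number here means a weaker inhibitor, a lower number a stronger inhibitor), where compound 2 gives 76 nM. Going by the values given here, compound 1 `O=C(O)Cc1sc(C(c2ccc(F)cc2)c2ccc(F)cc2)nc1-c1ccncc1` gives 40 nM in this assay, a number that lies within the scatter of the one for compound 2, so the two cannot be ordered. Compound 3 `COc1ccc(C(c2ccccn2)c2nc(-c3ccc(Cl)cc3)c(CC(=O)O)s2)cc1` gives 310 nM, which places compound 2 second highest of the three, with compound 3 the only one beyond its scatter. Among the compounds with values here, that gap is the single step among the measured compounds: a 4.1-fold higher number from compound 2 to compound 3 (0.61 log units; beyond the scatter).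

Compound 4 `O=C(O)Cc1sc(C(Cc2ccccc2)c2ccccc2)nc1-c1ccc(Cl)cc1` differs from compound 2 at the same saturated chain carbon bound to two aromatic carbons, but by a different exchange: benzyl in place of 4-methoxyphenyl on a saturated chain carbon bound to two aromatic carbons. Within the data shown here, no measured step swaps an aromatic ring for a benzyl group, so the step from compound 2 to compound 3 bears on it only as a sign that this position tolerates change with a modest loss. On that basis a modest rise is expected, a 2.6-fold higher number from compound 2 to compound 4 (0.42 log units; beyond the scatter). Compound 4 is therefore estimated at 200 nM, with a likely range from 60 nM to 700 nM.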

Compound 4, half-maximal inhibitory concentration: 510 nM
Estimate against measurement, compound 4: 2.6-fold (0.41 log units) below, within the range that was stated.
By their numbers in this assay, from the lowest: compounds 1 and 2 (each within the scatter of the next); then compounds 3 and 4 (each within the scatter of the next).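

Exchanging 4-methoxyphenyl for benzyl on this saturated chain carbon gives a 6.7-fold higher number from compound 2 to compound 4 (0.83 log units; beyond the scatter), so the loss seen earlier with one aromatic ring swapped for another, a 4.1-fold higher number from compound 2 to compound 3 (0.61 log units; beyond the scatter), is not confined to that kind of exchange. The benzyl exchange removes the oxygen and also changes how the aromatic ring is attached, and this single step cannot separate those two changes. No measurement shown explains the loss.

The compounds shown leave open whether the methoxy group or the way the ring is attached accounts for the step, which a 4-methoxybenzyl group or an unsubstituted phenyl ring in the same place would help to settle. They also leave open how a longer chain such as 2-phenylethyl, or an amine, would fare on this carbon.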